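Fluorobenzyl substitution in the shared core series

The compounds below may be only part of what the source reports. "The series", "measured", "known", "first", "only" and "open" are said of these compounds alone.

Measured compounds:
- compound 1, `CC1(C)c2[nH]nc(NC(=O)c3ccccc3)c2CN1Cc1ccccc1`, 1240 nM
- compound 2, `CC1(C)c2[nH]nc(NC(=O)c3ccccc3)c2CN1Cc1ccccc1F`, 450 nM
- compound 3, `CC1(C)c2[nH]nc(NC(=O)c3ccccc3)c2CN1Cc1cccc(F)c1F`, 200 nM

In an assay on Sf21 cells for inhibition of high affinity nerve growth factor receptor (Homo sapiens), read by HTRF, with a stated time of 30 min, in the presence of a further agent that is not named here (a lower number here means a stronger inhibitor, a higher number a weaker inhibitor), compound 2 stands second highest of the three numbers; compound 3 sits nearest with a lower number, compound 1 furthest with a higher number. Compound 4, `CC1(C)c2[nH]nc(NC(=O)c3ccccc3)c2CN1Cc1ccc(F)cc1F`, is not yet measured. Relative to compound 2 the change is fluoro in place of hydrogen on an aromatic carbon, so a second fluoro enters the benzyl ring on an aromatic carbon of a six-membered aromatic ring of carbon only.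

Among the measured compounds shown here, two measured steps bear on this. Each adds one fluoro to the benzyl ring: a 2.8-fold lower number from compound 1 to compound 2 (0.44 log units; beyond the scatter) and a 2.3-fold lower number from compound 2 to compound 3 (0.35 log units; beyond the scatter), both modest and beyond the scatter, both lowering the number. Compound 3 carries its second fluoro at a different ring position than compound 4 will, so the transfer is not exact, but the direction is consistent across the two steps. A modest lowering is therefore expected in this assay, of about a 1.8-fold lower number from compound 2 to compound 4 (0.26 log units; within the scatter).

Compound 4 is estimated at 250 nM, within 120 nM to 520 nM.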

Compound 4, half-maximal inhibitory concentration: 2320 nM
Compound 4: middle estimate off by 9.3-fold (0.97 log units), on the low side; measured number outside the range, above it.
By their numbers in this assay, from the lowest: compound 3; then compound 2; then compounds 1 and 4 (each within the scatter of the next).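

In this assay the effect of a second fluoro depends on where it sits: going from 2-fluorobenzyl to 2,4-difluorobenzyl gives a 5.2-fold higher number from compound 2 to compound 4 (0.71 log units; beyond the scatter) and so runs against the lowering seen on adding fluoro in compound 2 and compound 3. The two difluorobenzyl compounds are separated by a 12-fold higher number from compound 3 to compound 4 (1.06 log units; beyond the scatter) and this is the largest step in the set, although the groups differ only in the place of one fluoro. Against the unsubstituted benzyl the result is a 1.9-fold higher number from compound 1 to compound 4 (0.27 log units; within the scatter) and so compound 4 keeps no gain that can be told from the scatter.

Going by these compounds, it remains open whether a chloro or methoxy group on the same aromatic carbon, para to a large group, would follow the fluoro, or whether a lone fluoro there would do so. No measurement beyond these assay numbers bears on the reversal.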